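The compounds below may be only part of what the source reports. "The series", "measured", "known", "first", "only" and "open" are said of these compounds alone.

In a functional assay on A549 cells (Homo sapiens) for cytotoxicity, read by MTT assay, with a stated time of 24 h (on this read-out higher numbers stand for weaker inhibition and lower numbers for stronger inhibition), three compounds sharing one core have been measured. Compound 1 `Nc1cccn2cc(Cc3ccc(F)cc3)c(=O)nc12` gives > 1000000 nM, which is a limit of the assay. Compound 2 `Cc1ccc(Cc2cn3cc(Cl)ccc3nc2=O)cc1` gives > 1000000 nM, which is also a limit and not a number. That places it at the limit of > 1000000 nM in this assay, at which 2 of the 3 values shown sit. Only compound 3 `O=c1nc2ccc(Br)cn2cc1Cc1ccc(Cl)cc1` gives a number, 105000 nM. Compound 4 `O=c1nc2ccc(Cl)cn2cc1Cc1ccc(F)cc1` differs from compound 2 by one change, (fluoro in place of methyl on an aromatic carbon), fluoro in place of methyl on an aromatic carbon. Going by the values given here, with compound 3 at 105000 nM as the only number available, a modest shift toward stronger inhibition is expected. The result for compound 4 may again be only a limit. The expected size is an at least 2.5-fold lower number from compound 2 to compound 4 (0.39 log units; beyond the scatter). For compound 4, the estimated half-maximal inhibitory concentration is 400000 nM, within an expected range of 100000 nM to 1000000 nM.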

Compound 4, half-maximal inhibitory concentration: 98300 nM
The estimate for compound 4 lay 4.1-fold (0.61 log units) above the measured number; measured number outside the range, below it.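

Fluoro in place of methyl on an aromatic carbon, para to a large group, brings an at least 10-fold lower number from compound 2 to compound 4 (1.00 log units; beyond the scatter). Going by these compounds alone, this is the first pair differing in one place, and it shows that this single change can move the read-out off the limit. Compound 2 gives a limit of the assay and not a number: the limit of > 1000000 nM in this assay, at which 2 of the 4 values shown sit.

As far as these compounds go, the true size of the step therefore stays open. So does how an amine, a carboxylic acid or a longer chain at this position would compare with fluoro.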